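Adding a second fluoro to compound 1

The source may hold more compounds than are shown below. What is called first, only, known or untested is meant among the compounds shown, and "the series" means these compounds.

Among the measured compounds shown here, compound 1 (`O=C(NCc1ccc(S(=O)(=O)c2cccc(F)c2)cc1)c1cc2cnccc2[nH]1`) is the anchor of this small series: in a functional assay on A2780 cells (Homo sapiens) for inhibition, read by sulforhodamine B assay, with a stated time of 72 h (on this read-out lower numbers stand for stronger inhibition and higher numbers for weaker inhibition), compound 1 gives 11 nM as the only actual number so far. Compound 2 (`O=C(NCc1ccc(S(=O)(=O)c2ccccc2)cc1)c1cn2ccnc2cn1`) reads > 10000 nM as a limit of the assay. Compound 3 (`Cn1c(C(=O)NCc2ccc(S(=O)(=O)c3ccccc3)cc2)cc2cnccc21`) reads > 10000 nM as a limit too.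

Compound 4 (`O=C(NCc1ccc(S(=O)(=O)c2ccc(F)c(F)c2)cc1)c1cc2cnccc2[nH]1`) keeps the core of compound 1 and turns the 3-fluorophenyl into a 3,4-difluorophenyl, with fluoro in place of hydrogen on an aromatic carbon is the whole difference. For the measured compounds named here, no measured pair shows what such a change does, so the only anchor is compound 1 at 11 nM and the small size of the change. No clear direction is expected in this assay, and the expected 1.1-fold higher number from compound 1 to compound 4 (0.04 log units; within the scatter) stays within the usual scatter. In this assay compound 4 is estimated at 12 nM within an expected range from 3 nM to 50 nM until it is measured.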

Compound 4, half-maximal inhibitory concentration: 14 nM
The estimate for compound 4 lay 1.2-fold (0.07 log units) below the measured number; measured number inside the range.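

Going from 3-fluorophenyl to 3,4-difluorophenyl gives a 1.3-fold higher number from compound 1 to compound 4 (0.10 log units; within the scatter) in this assay, the first step in the series that can be read. The aromatic carbon ortho to a fluoro group and para to a large group therefore takes a fluoro in place of hydrogen without a change beyond the scatter. Among the compounds shown here, this holds only for this one small replacement on the core of compound 1, and the earlier compounds offered no comparison of this kind.

From the compounds shown here alone, what a methoxy group, an amine or a carboxylic acid would do on this same carbon stays open, as does the contribution of the existing fluoro group in compound 1. The other steps cannot be read, as the remaining compounds differ from compound 1 in more than one place and give only limits: the limit of > 10000 nM in this assay, at which 2 of the 4 values shown sit.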